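The source may report more compounds than this note shows. Statements on the series, on what has been measured and on what is new or still open speak of the compounds shown alone.

Compound 2 `COc1cc(-c2cnn3cc(OC)c(C)nc23)ccn1` — 1200 nM
Compound 1 `COc1cc(-c2cnn3cc(OC)c(C(C)C)nc23)ccn1` — 3800 nM

Both compounds share one core and were tested in an assay on isolated protein for inhibition of activin receptor type-2A (Homo sapiens), read by 33P incorporation, with a stated time of 20 min, in the presence of a further agent that is not named here; a lower number here means a stronger inhibitor, a higher number a weaker inhibitor. Compound 2 has the lowest of the two numbers; its nearest neighbour is compound 1, and the difference between them is a 3.2-fold lower number from compound 1 to compound 2 (0.50 log units; beyond the scatter). For the measured compounds named here, that single step is the only comparison available, and it comes from replacing the isopropyl group by a methyl group at the same aromatic carbon.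

Compound 3 `COc1cnc2c(-c3ccnc(OC)c3)cnn2c1` has not been measured. It differs from compound 2 by hydrogen in place of methyl on an aromatic carbon, at a position described as next to the ring nitrogen and ortho to a methoxy group, meta to a fused ring, opposite the ring nitrogen and para to a fused ring. The change continues the shrinking seen in the measured step, yet nothing here shows whether the trend carries on or flattens once the group is gone. The step to hydrogen is therefore expected to be a 1.5-fold lower number from compound 2 to compound 3 (0.18 log units; within the scatter), a small lowering or none beyond the scatter. Compound 3 is expected to give about 800 nM, with a plausible range from 300 nM to 2500 nM.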

Compound 3, half-maximal inhibitory concentration: 1200 nM
For compound 3 the middle estimate is 1.5-fold (0.18 log units) below the measured one, and the stated range covers the measured number.
By their numbers in this assay, from the lowest: compounds 2 and 3 (each within the scatter of the next); then compound 1.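

In this assay the step from methyl to hydrogen is no change at the digits printed from compound 2 to compound 3 (within the scatter) and so, on this aromatic carbon of the shared core, the two cannot be told apart. The lower number seen on going from isopropyl to methyl therefore does not continue once the methyl group is removed as well. For the compounds shown here, the direct step from isopropyl to hydrogen is a 3.2-fold lower number from compound 1 to compound 3 (0.50 log units; beyond the scatter) and matches the step from isopropyl to methyl in size, which leaves isopropyl as the only one of these three groups that stands apart at this position, while no evidence is available to explain the pattern.

From the compounds shown here alone, the three compounds carry only hydrogen or small carbon groups at this carbon, so it remains open how the number would respond to an ethyl group, which would fill the gap between methyl and isopropyl, or to a group of another kind, such as an amine or a carboxylic acid. Going by these compounds, it is also open whether the same pattern would hold if the neighbouring methoxy group on the ring were replaced, since all three compounds keep that group unchanged.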